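From Free Acid to tert-Butyl Ester: An Expected Recovery

The source may hold more compounds than are shown below. What is called first, only, known or untested is meant among the compounds shown, and "the series" means these compounds.

The series rests on the core of compound 1 `CC(C)c1cccc(C(C)C)c1NC(=O)CC(=O)OC(c1ccccc1)c1ccccc1`. In an assay on microsomes from intestine for inhibition of acyl-CoA:cholesterol acyltransferase (Oryctolagus cuniculus) (on this read-out higher numbers stand for weaker inhibition and lower numbers for stronger inhibition), compound 1 gives 38 nM. Compound 2 `CC(C)c1cccc(C(C)C)c1NC(=O)CC(=O)O` carries the free acid where compound 1 carries its ester. For compound 2 the result in this assay is > 5000 nM, which is a limit of the assay and not a measured number. For the measured compounds named here, compound 2 therefore stands at the limit of > 5000 nM in this assay, at which 1 of the 2 values shown sits, and no step between it and compound 1 is computed here, so the pair shows only that the ester has a measured value and the acid does not.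

Compound 3 `CC(C)c1cccc(C(C)C)c1NC(=O)CC(=O)OC(C)(C)C` has not yet been measured. It differs from compound 2 by tert-butyl in place of hydrogen on an oxygen next to a carbonyl group. Because compound 1 gives 38 nM with an ester in the same place, an ester is expected to matter. The step toward stronger inhibition is expected to be large, estimated as an at least 10-fold lower number from compound 2 to compound 3 (1.00 log units; beyond the scatter). Compound 3 is thus expected to reach 500 nM in this assay, within 100 nM to 4000 nM.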

Compound 3, half-maximal inhibitory concentration: 130 nM
Estimate against measurement, compound 3: 3.8-fold (0.59 log units) above; measured number inside the range.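

With compound 3, the ester at this place no longer rests on compound 1 alone: in this assay, tert-butyl in place of hydrogen on an oxygen next to a carbonyl group gives an at least 38-fold lower number from compound 2 to compound 3 (1.58 log units; beyond the scatter). The tert-butyl group contains no ring, so a ring in the group on this oxygen is not required for inhibition in the nanomolar range, with compound 1 at 38 nM and compound 3 at 130 nM. The value of compound 2 is a limit of the assay and not a number, so the full size of the step stays unknown: the limit of > 5000 nM in this assay, at which 1 of the 3 values shown sits.

The two esters differ too much in shape of group to show which feature of the group on this oxygen sets the value, and a methyl ester, an ethyl ester or a longer chain there would begin to fill the gap between hydrogen and tert-butyl. Going by these compounds, it also remains open whether the oxygen itself is needed, which an amide or a ketone at this place would test, and whether the diisopropyl-substituted part of the shared core tolerates any change.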